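The compounds below may be only part of what the source reports. "The series", "measured", "known", "first", "only" and "open" are said of these compounds alone.

In a functional assay on HCT-116 cells (Homo sapiens) for inhibition, read by sulforhodamine B assay, with a stated time of 48 h, tested at 10 uM (a higher number here means a weaker effect of the compound at the concentration tested, a lower number a stronger effect), compound 3 `COc1cc(Cl)cc(-c2nn(-c3cccc(NC(=O)c4cccc(C(F)(F)F)c4)c3)cc2-c2ccncc2)c1` gives 34.1%, the highest of the three numbers in hand. Its neighbours are compound 1 `COc1cc(Cl)cc(-c2nn(-c3cccc(NC(=O)Nc4ccc(Cl)c(Cl)c4)c3)cc2-c2ccncc2)c1`, which gives 9.22%, and compound 2 `COc1cc(Cl)cc(-c2nn(-c3cccc(NC(=O)Nc4cccc(C(F)(F)F)c4)c3)cc2-c2ccncc2)c1`, which gives 5.07%; the steps of a number 24.9 percentage points higher from compound 1 to compound 3 (beyond the scatter) and a number 29 percentage points higher from compound 2 to compound 3 (beyond the scatter) both turn on the carbonyl carbon, not on the aryl ring. Compound 4 `COc1cc(Cl)cc(-c2nn(-c3cccc(NC(=O)c4cc(C(F)(F)F)cc(C(F)(F)F)c4)c3)cc2-c2ccncc2)c1` differs from compound 3 by trifluoromethyl in place of hydrogen on an aromatic carbon. Within the data shown here, no measured step tests this change directly; the nearest comparison is a number 4.2 percentage points lower from compound 1 to compound 2 (within the scatter), which exchanges groups on that same aryl ring and stays within the scatter. One therefore expects no step beyond the scatter, a number 4.1 percentage points lower from compound 3 to compound 4 (within the scatter). For compound 4 in this assay the estimate is 30%, with a range from 12% to 55%.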

Compound 4, a percentage reported as activity, at one concentration (the size of the read-out at that concentration, not a potency): 35.2%
Compound 4: middle estimate off by 5.2 percentage points, on the low side; low and high end bracket the measured number.
By their numbers in this assay, from the lowest: compounds 2 and 1 (each within the scatter of the next); then compounds 3 and 4 (each within the scatter of the next).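

Adding a trifluoromethyl on an aromatic carbon, meta to a trifluoromethyl group, gives in this assay a number 1.1 percentage points higher from compound 3 to compound 4 (within the scatter). The earlier ring exchange came from compounds with an amino group on the carbonyl carbon, whereas this step shows that, with the aryl ring directly on the carbonyl carbon, this added group leaves the read-out within the scatter. Nothing available here bears on the reason for this result. Going by these compounds, whether an amine or a carboxylic acid at this position would also stay within the scatter remains open, as does the effect of this addition on compounds with the amino group on the carbonyl carbon.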